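Swapping a tert-butyl for two methyls on the shared core

This account rests on a few compounds, and the source may have more. Where it says the series, first, only, none or still open, it means among the compounds named here.

Of the compounds shown here, three of one shared core have been tested in a functional assay on MCF7 cells (Homo sapiens) for inhibition, read by CCK-8 assay, with a stated time of 48 h; a higher number here means a weaker inhibitor, a lower number a stronger inhibitor. Compound 1 `COc1cc(-c2ccnc3c(-c4ccc(C)cc4)cnn23)cc(OC)c1OC` reaches only the limit of the assay, > 10000 nM, so no number is known for it. The same holds for compound 3 `COc1cc(-c2cc3nccc(-c4c[nH]c5ccccc45)n3n2)cc(OC)c1OC`, which gives the limit > 10000 nM. Compound 2 `COc1cc(-c2ccnc3cc(-c4ccc(C(C)(C)C)cc4)nn23)cc(OC)c1OC` also sits at the limit, with > 10000 nM. Compound 2 thus stands at the limit of > 10000 nM in this assay, at which 3 of the 3 values shown sit, and nothing in the numbers sets it apart from the other two measured compounds.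

Compound 4 `COc1cc(-c2ccnc3cc(-c4ccc(C)c(C)c4)nn23)cc(OC)c1OC` has not yet been measured. It differs from compound 2 in one place: 3,4-dimethylphenyl in place of 4-(tert-butyl)phenyl on an aromatic carbon. A 4-(tert-butyl)phenyl group thus gives way to a 3,4-dimethylphenyl group on an aromatic carbon of the shared core.

Going by the values given here, no measured pair differing in one place exists here, so the size of such a step is unknown. With all three measured compounds at the limit, there is nothing to suggest that this change brings the number down into the measurable range. The expected step from compound 2 to compound 4 is a step that the limit leaves unreadable from compound 2 to compound 4, meaning none beyond the scatter. Compound 4 is therefore expected to give about 15000 nM in this assay, within a range from 5000 nM to 50000 nM, and most likely again only a limit.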

Compound 4, half-maximal inhibitory concentration: 26 nM
For compound 4 the middle estimate is 580-fold (2.76 log units) above the measured one; measured number below the stated range.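

In this assay the change brings an at least 380-fold lower number from compound 2 to compound 4 (2.58 log units; beyond the scatter), so on this aromatic carbon of the shared core, the choice of group separates a measurable inhibitor from one with no readable number. The change is also a modest one: both groups keep one six-membered aromatic ring of carbon only, with no hydrogen-bond donors or acceptors, and they differ in what that ring carries, a tert-butyl group in one and two methyl groups in the other. Compound 2 gives only a limit, so the true size of the step stays unknown, and compound 4 is the only compound here with an actual number: the limit of > 10000 nM in this assay, at which 3 of the 4 values shown sit.

From the compounds shown here alone, it remains open whether the gain depends on having both methyl groups, or simply on the loss of the tert-butyl group, and a single methyl, a chlorine or a methoxy group on the same phenyl ring would help to separate these two readings. Going by these compounds, it is also open how far this position tolerates other kinds of group, such as an amine or a carboxylic acid on that ring.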